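Toxicity notes on the pyrazole carboxamide series

The source may hold more compounds than are shown below. What is called first, only, known or untested is meant among the compounds shown, and "the series" means these compounds.

Compound 1 `CC(C)Cc1nn(-c2nccs2)cc1C(=O)NCc1cccc(F)c1` was tested in a toxicity assay on HepG2 2.2.15 cells (Homo sapiens) for cytotoxicity, read by CCK-8 assay, with a stated time of 8 days; on this read-out lower numbers stand for higher toxicity in this test and higher numbers for lower toxicity in this test. In this assay compound 1 gives > 100000 nM, which is a limit of the assay and not a number, as recorded in the limit of > 100000 nM in this assay, at which 1 of the 2 values shown sits. Among the compounds with values here, compound 2 `CCOC(=O)c1cn(-c2ccccc2[N+](=O)[O-])nc1CC(C)C`, built on a different core, gives 4850 nM in this assay; no step between compound 1 and compound 2 is defined, so the two values are only placed side by side.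

Compound 3 `CC(C)Cc1nn(-c2nccs2)cc1C(=O)NCc1ccc(N)cc1` has not yet been measured in this assay. It differs from compound 1 by 4-aminophenyl in place of 3-fluorophenyl on a saturated chain carbon bound to an amide-type nitrogen. Within the data shown here, no measured step covers such a change, so no size can be read off, and the expectation is for no step beyond the scatter, with the limit likely reached again. The expected step from compound 1 to compound 3 is a step that the limit leaves unreadable from compound 1 to compound 3. For compound 3 the estimate in this assay is 150000 nM, with a range from 60000 nM to 400000 nM.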

Compound 3, half-maximal cytotoxic concentration: > 100000 nM
Compound 3 ended at the assay's limit (the forecaster's own chance of this, stated with the estimate: 75%); the middle value does not contradict the limit.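

No step can be read from compound 1 to compound 3, because both sit at a limit of the assay and not at a number: the limit of > 100000 nM in this assay, at which 2 of the 3 values shown sit. The compounds shown leave open whether 4-aminophenyl in place of 3-fluorophenyl changes toxicity at all in this assay.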